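Side-chain variation and oral exposure in the benzothiazole series

The compounds below may be only part of what the source reports. "The series", "measured", "known", "first", "only" and "open" are said of these compounds alone.

Compound 3 `CCOC(=O)NCCNc1nc(C)c(-c2nc3ccccc3s2)c(N[C@@H]2C[C@H](CO)[C@@H](O)[C@H]2O)n1` carries the shared core with a 2-((ethoxycarbonyl)amino)ethyl chain on the ring nitrogen. In an ADME assay on the whole organism (plasma) for pharmacokinetics, with Rattus norvegicus as the target, with a stated time of 6 h, at a dose of 10 mg/kg by the oral route (on this read-out lower numbers stand for lower exposure and higher numbers for higher exposure at the dose given), compound 3 gives 151 ng.h/mL, the lowest of the three numbers measured. Compound 1 `CCOCCNc1nc(C)c(-c2nc3ccccc3s2)c(N[C@@H]2C[C@H](CO)[C@@H](O)[C@H]2O)n1` gives 1100 ng.h/mL and compound 2 `Cc1nc(NCCOC(C)C)nc(N[C@@H]2C[C@H](CO)[C@@H](O)[C@H]2O)c1-c1nc2ccccc2s1` gives 426 ng.h/mL. The steps within the measured set all sit at the side chain: a 2.6-fold lower number from compound 1 to compound 2 (0.41 log units; beyond the scatter), a 7.3-fold lower number from compound 1 to compound 3 (0.86 log units; beyond the scatter) and a 2.8-fold lower number from compound 2 to compound 3 (0.45 log units; beyond the scatter).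

Compound 4 `Cc1nc(NCc2cccnc2)nc(N[C@@H]2C[C@H](CO)[C@@H](O)[C@H]2O)c1-c1nc2ccccc2s1` differs from compound 3 in that part alone: pyridin-3-yl in place of ((ethoxycarbonyl)amino)methyl on a saturated chain carbon bound to a nitrogen on an aromatic ring. For the measured compounds named here, none of the measured steps swaps a chain for an aromatic ring, so there is no direct precedent. What the three steps do show is that changes at this position moved the read-out by modest amounts, with the carbamate-bearing compound 3 at the bottom. Removing the (ethoxycarbonyl)amino group is therefore expected to give a step of a 2.3-fold higher number from compound 3 to compound 4 (0.37 log units; beyond the scatter), in the direction of higher exposure, with wide uncertainty. Compound 4 is estimated at 350 ng.h/mL, within 90 ng.h/mL to 1300 ng.h/mL.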

Compound 4, area under the concentration-time curve: 9.57 ng.h/mL
Compound 4: middle estimate off by 37-fold (1.56 log units), on the high side; measured number outside the range, below it.
By their numbers in this assay, from the lowest: compound 4; then compound 3; then compound 2; then compound 1.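

In this assay, for the compounds shown here, the change to pyridin-3-yl gives a 16-fold lower number from compound 3 to compound 4 (1.20 log units; beyond the scatter) and a 45-fold lower number from compound 2 to compound 4 (1.65 log units; beyond the scatter) and a 110-fold lower number from compound 1 to compound 4 (2.06 log units; beyond the scatter), each a larger step than any among the earlier compounds. The position therefore spans a much wider range than the ether and carbamate chains alone showed, and the bottom of the series moves from compound 3 to compound 4. The link between an aromatic ring on this chain carbon and low exposure rests on compound 4 alone.

Still open, going by these compounds, is whether the fall follows the ring nitrogen or the aromatic ring itself, which phenyl in place of pyridin-3-yl would separate, and whether a longer chain carrying the pyridin-3-yl behaves the same way. Nothing measured here accounts for the fall in exposure.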